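The compounds below may be only part of what the source reports. "The series", "measured", "known", "first", "only" and "open" are said of these compounds alone.

Three compounds have been measured so far in an ADME assay on J774.A1 cells (Mus musculus) for cytotoxicity, read by MTT assay, with a stated time of 48 h (on this read-out higher numbers stand for lower toxicity in this test and lower numbers for higher toxicity in this test), with these results:

- compound 1 `C/C(=C\c1ccccc1)C(=O)/C=C/c1ccccc1` gives 34500 nM
- compound 2 `COc1ccc(/C=C/C(=O)/C(C)=C/c2ccccc2)cc1` gives 51000 nM
- compound 3 `C/C(=C\c1ccccc1)C(=O)/C=C/c1ccc(N(C)C)cc1` gives 20200 nM

Compound 1 holds the second highest of these three numbers, yet both of the others lie within the usual scatter of it. Compound 4 `C/C(=C\c1ccc([N+](=O)[O-])cc1)C(=O)/C=C/c1ccccc1` has not been measured. Among the compounds with values here, its one change from compound 1 is nitro in place of hydrogen on an aromatic carbon and it reads as nitro in place of hydrogen on an aromatic carbon, para to a large group.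

Two measured steps also add a group to an aromatic carbon of compound 1. They are a 1.5-fold higher number from compound 1 to compound 2 (0.17 log units; within the scatter) and a 1.7-fold lower number from compound 1 to compound 3 (0.23 log units; within the scatter) and neither of them brings in a nitro. Exchanging those two added groups gives a 2.5-fold lower number from compound 2 to compound 3 (0.40 log units; beyond the scatter) and that modest step is the largest seen. Adding a group has therefore moved the number only slightly in these two cases, although no measurement yet shows what a nitro does. In this assay the estimated change is a 1.2-fold lower number from compound 1 to compound 4 (0.06 log units; within the scatter) and so no step beyond the scatter is expected. For compound 4 the estimate is 30000 nM with an expected range of 12000 nM to 70000 nM around it.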

Compound 4, half-maximal cytotoxic concentration: 47300 nM
For compound 4 the middle estimate is 1.6-fold (0.20 log units) below the measured one; measured number inside the range.
By their numbers in this assay, from the lowest: compounds 3, 1, 4 and 2 (each within the scatter of the next, the first and the last beyond it).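

In this assay, nitro in place of hydrogen on an aromatic carbon, para to a large group, gives a 1.4-fold higher number from compound 1 to compound 4 (0.14 log units; within the scatter). Within the data shown here, this is the first measurement of a nitro in the set, and it shows that adding these 3 heavy atoms, with 2 hydrogen-bond acceptors and no net charge, at this place leaves the read-out indistinguishable from that of compound 1. Compounds 2, 3 and 4 now all lie within the scatter of compound 1, so none of the three added groups has yet given a clear step away from it, while nothing available explains why the number holds steady with the nitro in place.

The compounds shown leave open what a carboxylic acid, a primary amine or a longer alkyl chain would do at this same place, and whether methoxy or dimethylamino placed here would match the nitro. They also leave open whether the nitro would give a similar result at another aromatic carbon, since one substitution at one place cannot show how far this tolerance extends.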